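The source may hold more compounds than are shown below. What is called first, only, known or untested is meant among the compounds shown, and "the series" means these compounds.

Compound 1 `Nc1cccc2c(-c3cccc(NC(=O)c4nccs4)c3)ccnc12`: 1700 nM
Compound 2 `COc1ccc(C(=O)Nc2cccc(-c3ccnc4c(NC(C)=O)cccc34)c2)cc1OC`: 270 nM

The two compounds share a common core and differ in the amide attached to the pendant phenyl ring. In a functional assay on MDA-MB-435 cells (Homo sapiens) for antiproliferative activity, read by sulforhodamine B assay, with a stated time of 48 h (on this read-out higher numbers stand for weaker inhibition and lower numbers for stronger inhibition), compound 1 gives 1700 nM. Compound 2, which carries a 3,4-dimethoxyphenyl amide, gives 270 nM in this assay, the lower of the two numbers; compound 1 sits a good way higher, and that gap lies beyond the usual scatter.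

Compound 3 `CC(=O)Nc1cccc2c(-c3cccc(NC(=O)c4ccc5c(c4)OCCO5)c3)ccnc12` has not yet been tested. It differs from compound 2 in one place: 2,3-dihydro-1,4-benzodioxin-6-yl in place of 3,4-dimethoxyphenyl on a carbonyl carbon. The two oxygen atoms stay, but they are tied back into a ring fused to the aromatic ring rather than standing as two separate methoxy groups. No measured pair in this set isolates such a change, so there is no shown step to lean on. Given how close the two groups are in size and in their count of acceptors, the step from compound 2 is expected to be small, in either direction, and probably not beyond the scatter: a 1.1-fold higher number from compound 2 to compound 3 (0.05 log units; within the scatter). Compound 3 is therefore estimated at 300 nM in this assay, within a range from 120 nM to 800 nM.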

Compound 3, half-maximal inhibitory concentration: 27 nM
Beside the measured number, compound 3's estimate is 11-fold (1.05 log units) above it; the measured number lies below the stated range.
By their numbers in this assay, from the lowest: compound 3; then compound 2; then compound 1.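

In this assay, replacing 3,4-dimethoxyphenyl with 2,3-dihydro-1,4-benzodioxin-6-yl gives a 10-fold lower number from compound 2 to compound 3 (1.00 log units; beyond the scatter) and thus a change beyond the scatter, although the two groups match in their heavy atoms, their oxygen atoms and their hydrogen-bond acceptors. The result shows that the read-out at this position, on a carbonyl carbon whose other neighbours are an amide-type nitrogen, can separate two groups that those counts do not distinguish, which the earlier pair could not show because compound 1 and compound 2 differ in more than one place. No evidence is available on what lies behind this step.

The compounds shown leave open whether a 1,3-benzodioxol-5-yl group, with its five-membered ring, or a phenyl ring bearing a single methoxy group would stand nearer to compound 2 or to compound 3. They also leave open whether the same exchange would give a similar step on a core carrying the amine of compound 1 in place of the acetamide of compound 2 and compound 3.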